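Cytotoxicity notes: nitrobenzyl to tert-butylbenzyl swap

The compounds below may be only part of what the source reports. "The series", "measured", "known", "first", "only" and "open" are said of these compounds alone.

Compound 2 `COC(=O)c1ccc(NCc2cncn2Cc2ccc([N+](=O)[O-])cc2)cc1-c1ccccc1` sits at a limit in a toxicity assay on NIH3T3 cells (Mus musculus) for cytotoxicity, read by resazurin assay; on this read-out lower numbers stand for an effect already at smaller amounts and higher numbers for an effect only at larger amounts of compound. In this assay compound 2 gives > 10000 nM, which is a limit of the measurement and not a number (the limit of > 10000 nM in this assay, at which 1 of the 3 values shown sits). Compound 3 `O=[N+]([O-])c1ccc(Cn2cncc2CNc2cccc(-c3ccccc3)c2)cc1` gives 10000 nM in this assay, and the step of a number no higher from compound 2 to compound 3 (the limit leaves the size open) leaves its size open. Compound 1 `Cc1cccc(-c2cccc(NCc3cncn3Cc3ccccc3)c2)c1C` also sits at a limit. In this assay compound 1 gives > 1000 nM, a limit and not a number (the limit of > 1000 nM in this assay, at which 1 of the 3 values shown sits). Compound 4 `COC(=O)c1ccc(NCc2cncn2Cc2cccc(C(C)(C)C)c2)cc1-c1ccccc1` is not yet measured and differs from compound 2 by 3-(tert-butyl)phenyl in place of 4-nitrophenyl on a saturated chain carbon bound to an aromatic nitrogen. Among the compounds with values here, the single measured step concerns a different place, so no measured step bears on this change. The expected step is a number no higher from compound 2 to compound 4 (the limit leaves the size open), none beyond the scatter. For compound 4 the estimate in this assay is 10000 nM, with a range from 3000 nM to 30000 nM.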

Compound 4, half-maximal effective concentration: > 1000 nM
Compound 4: only a limit was reported; the forecaster's own chance of this, stated with the estimate: 60%; the middle value is on the limit's open side.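

In this assay compound 2 and compound 4 both give limits, not numbers, and the step between them cannot be read. From the compounds shown here alone, what 3-(tert-butyl)benzyl in place of 4-nitrobenzyl does to the value in this assay stays open.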